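The source may hold more compounds than are shown below. What is called first, only, known or untested is meant among the compounds shown, and "the series" means these compounds.

Compound 1 `O=C(COc1cccc2ccccc12)N/N=C/c1ccc(O)cc1` and compound 2 `O=C(COc1cccc2ccccc12)N/N=C/c1cccc(O)c1` share one core; the difference between them is 3-hydroxyphenyl in place of 4-hydroxyphenyl on a carbon with a double bond to nitrogen. In an ADME assay on HEL cells (Homo sapiens) for cytotoxicity (a higher number here means that more compound is tolerated, a lower number that less compound is tolerated), compound 1 gives 60.6 ug/mL, and compound 2 gives 62.7 ug/mL, so a 1.0-fold higher number from compound 1 to compound 2 (0.01 log units; within the scatter). Compound 3 `O=C(COc1cccc2ccccc12)N/N=C/c1ccc([N+](=O)[O-])cc1` differs from compound 1 by nitro in place of hydroxy on an aromatic carbon; in this assay compound 3 gives 14.2 ug/mL, which is a 4.3-fold lower number from compound 1 to compound 3 (0.63 log units; beyond the scatter). Compound 4 `O=C(COc1cccc2ccccc12)N/N=C/c1cccc([N+](=O)[O-])c1` has not yet been measured. It differs from compound 2 by nitro in place of hydroxy on an aromatic carbon, the same kind of change as that from compound 1 to compound 3, though here the group sits meta to a large group rather than para to it. Compound 4 is expected to give 15 ug/mL, somewhere between 7 ug/mL and 35 ug/mL, because the same kind of change gave a 4.3-fold lower number from compound 1 to compound 3 (0.63 log units; beyond the scatter). That estimate means a 4.2-fold lower number from compound 2 to compound 4 (0.62 log units; beyond the scatter).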

Compound 4, half-maximal cytotoxic concentration in the HEL assay: 61.2 ug/mL
Compound 4: the middle estimate sits 4.1-fold (0.61 log units) below what was measured; the measured number lies above the stated range.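

In the HEL assay, compound 2 gives 62.7 ug/mL and compound 4 gives 61.2 ug/mL with nitro in place of hydroxy, which is a 1.0-fold lower number from compound 2 to compound 4 (0.01 log units; within the scatter), so the step seen on the core of compound 1 did not carry over to the core of compound 2: the same change on two cores in the HEL assay, a 4.3-fold lower number (0.63 log units; beyond the scatter) from compound 1 to compound 3 and a 1.0-fold lower number (0.01 log units; within the scatter) from compound 2 to compound 4, 4.2-fold (0.62 log units) apart, beyond the scatter of two such steps This shows that, in this series, the size of this change cannot simply be copied from one core to another, but with a single pair on each core it does not show why the two steps differ. In a physicochemical assay for lipophilicity, measured as octanol-water partition (on this read-out lower numbers stand for lower lipophilicity and higher numbers for higher lipophilicity), compound 2 gives 3.73 and compound 4 gives 3.97 with the same change, which is a number 0.24 log units higher from compound 2 to compound 4 (within the scatter), yet this pair has no partner on the other core to set it against.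

Going by these compounds, it remains open whether an amine or a carboxylic acid in place of hydroxy would give two different steps on these cores as well.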